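Capping one carboxy group as its methyl ester

The source may hold more compounds than are shown below. What is called first, only, known or untested is meant among the compounds shown, and "the series" means these compounds.

In a functional assay on HCC827 cells (Homo sapiens) for inhibition, read by MTT assay, with a stated time of 72 h (a lower number here means a stronger inhibitor, a higher number a weaker inhibitor), compound 1 `CC(=O)Oc1ccc(C(=O)C2=C(O)[C@]3(CC=C(C)C)C[C@@H](C/C=C(\C)CCC=C(C)C)[C@](C)(CCC=C(C)C)[C@](CC=C(C)C)(C2=O)C3=O)cc1OC(C)=O` reads > 20000 nM as a limit of the assay and not a number. As far as these compounds go, compound 2 `CC(C)=CCC/C(C)=C/C[C@@H]1C[C@]2(CC=C(C)C)C(=O)[C@@](CC=C(C)C)(C(=O)C(C(=O)c3ccc(OCC(=O)O)c(OCC(=O)O)c3)=C2O)[C@@]1(C)CCC=C(C)C` reads > 20000 nM in this assay and this too is only a limit, so its true position is unknown. Compound 3 `COC(=O)COc1ccc(C(=O)C2=C(O)[C@]3(CC=C(C)C)C[C@@H](C/C=C(\C)CCC=C(C)C)[C@](C)(CCC=C(C)C)[C@](CC=C(C)C)(C2=O)C3=O)cc1OCC(=O)O` differs from compound 2 by methyl in place of hydrogen on an oxygen next to a carbonyl group, carboxy to methoxycarbonyl. Going by the values given here, no measured step guides this change, so only a small move toward stronger inhibition is expected, and it may stay hidden at the limit. The expected size of an at least 1.3-fold lower number from compound 2 to compound 3 (0.12 log units; that floor lies within the scatter) is an estimate only. For compound 3 the estimated value is 15000 nM with an expected range from 6000 nM to 30000 nM in this assay here.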

Compound 3, half-maximal inhibitory concentration: > 20000 nM
Compound 3 was reported as a limit (the forecaster's own chance of this, stated with the estimate: 60%); at least 1.3-fold (0.12 log units) between middle value and limit.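

No step can be read from compound 2 to compound 3, as both stand at the same limit: the limit of > 20000 nM in this assay, at which 3 of the 3 values shown sit.

The compounds shown leave open whether carboxy to methoxycarbonyl changes inhibition at all, and where the true values of compound 1, compound 2 and compound 3 lie.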